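The source may hold more compounds than are shown below. What is called first, only, known or untested is meant among the compounds shown, and "the series" means these compounds.

Going by the values given here, in a physicochemical assay, read by spectrophotometry (on this read-out higher numbers stand for weaker inhibition and lower numbers for stronger inhibition), two compounds on the shared core have numbers so far: compound 1 `CCN(CC)C(=O)COc1ccc(-c2cc(=O)c3c(O)c(O)c(O)cc3o2)cc1` gives 81300 nM, and compound 2 `O=C(COc1ccc(-c2cc(=O)c3c(O)c(O)c(O)cc3o2)cc1)N1CCOCC1` gives 83300 nM. Among the compounds with values here, compound 2 therefore stands level with compound 1, the only comparison available, and the two cannot be told apart. Next in the series is compound 3 `CN(C)CCCOc1ccc(-c2cc(=O)c3c(O)c(O)c(O)cc3o2)cc1`, which differs from compound 2 as follows: 2-(dimethylamino)ethyl in place of (morpholin-4-yl)carbonyl on a saturated chain carbon bound to an oxygen on an aromatic ring. In short, 2-(dimethylamino)ethyl takes the place of (morpholin-4-yl)carbonyl on a saturated chain carbon bound to an oxygen on an aromatic ring.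

Within the data shown here, only one measured step bears on this change: a 1.0-fold higher number from compound 1 to compound 2 (0.01 log units; within the scatter). Among the measured compounds shown here, that step exchanged one group on a carbonyl carbon for another, whereas in compound 3 the carbonyl itself is gone, and no measured compound lacks it. The guidance is therefore weak, and the range must stay wide. For the measured compounds named here, with that single step as the only precedent, no step beyond the scatter is expected in this assay, and no direction is favoured. The expected step is a 1.1-fold lower number from compound 2 to compound 3 (0.05 log units; within the scatter). For compound 3 the estimated value is 75000 nM, with an expected range from 30000 nM to 170000 nM.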

Compound 3, half-maximal inhibitory concentration: 231000 nM
Compound 3: the middle estimate sits 3.1-fold (0.49 log units) below what was measured, and the stated range ends below it.
By their numbers in this assay, from the lowest: compounds 1 and 2 (each within the scatter of the next); then compound 3.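

In this assay this place on the side chain can move the number: a 2.8-fold higher number from compound 2 to compound 3 (0.44 log units; beyond the scatter) and a 2.8-fold higher number from compound 1 to compound 3 (0.45 log units; beyond the scatter) are steps of the same modest size in the same direction, both beyond the scatter. The earlier pair showed only a 1.0-fold higher number from compound 1 to compound 2 (0.01 log units; within the scatter) with the carbonyl kept, whereas replacing the whole carbonyl-bearing group with 3-(dimethylamino)propyl goes towards weaker inhibition, whether morpholin-4-yl or diethylamino sat on the carbonyl carbon. No measurement available here accounts for this shift.

The change removes the carbonyl and brings in a dimethylamino end at once, and the compounds shown do not separate these two parts, which a 3-(morpholin-4-yl)propyl group on the same oxygen would help to pull apart. Also open, going by these compounds, is how a carboxylic acid on the saturated chain carbon, or a longer chain ending in dimethylamino, would read on this scale.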